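The source may hold more compounds than are shown below. What is called first, only, known or untested is meant among the compounds shown, and "the series" means these compounds.

Compound 1 `COc1ccc(Oc2ccccc2-c2ccsc2S(=O)(=O)N2CCN(C(=S)Nc3ccc([N+](=O)[O-])cc3)CC2)cc1OC` and compound 2 `COc1ccc(Oc2ccc([N+](=O)[O-])cc2-c2ccsc2S(=O)(=O)N2CCN(C(=S)Nc3ccc([N+](=O)[O-])cc3)CC2)cc1OC` share a core and differ by nitro in place of hydrogen on an aromatic carbon. In an ADME assay on HEK-293T cells (Homo sapiens) for cytotoxicity, read by CCK-8 assay, with a stated time of 48 h (a lower number here means a stronger inhibitor, a higher number a weaker inhibitor), compound 1 gives > 20000 nM, which is a limit of the assay. Compound 2 gives > 50000 nM in this assay, also a limit. The step that the two limits leave unreadable from compound 1 to compound 2 therefore cannot be sized. Compound 3 `O=S(=O)(c1sccc1-c1ccccc1Oc1ccc(O)c(O)c1)N1CCN(C(=S)Nc2cc(C(F)(F)F)cc(C(F)(F)F)c2)CC1` gives > 20000 nM in this assay, a limit as well; how its core differs from that of compound 1 is not broken down here. Compound 4 `O=[N+]([O-])c1ccc(Oc2ccc(O)c(O)c2)c(-c2ccsc2S(=O)(=O)N2CCN(C(=S)Nc3cc(C(F)(F)F)cc(C(F)(F)F)c3)CC2)c1` differs from compound 3 by nitro in place of hydrogen on an aromatic carbon, the same kind of change as before, the place now being para to a 3,4-dihydroxyphenoxy group rather than a 3,4-dimethoxyphenoxy group. For compound 4 a step that the limit leaves unreadable from compound 3 to compound 4 is expected, resting on the limit of > 20000 nM in this assay, at which 2 of the 3 values shown sit, and on (the limit of > 50000 nM in this assay, at which 1 of the 3 values shown sits). Compound 4 is thus estimated at 30000 nM, between 15000 nM and 70000 nM.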

Compound 4, half-maximal inhibitory concentration: > 20000 nM
Compound 4 ended at the assay's limit (the forecaster's own chance of this, stated with the estimate: 85%); the middle value is on the limit's open side.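

In this assay, going by these compounds alone, compound 4 gives > 20000 nM, a limit of the assay, so no step from compound 3 to compound 4 can be read. All the compounds shown sit at limits, which leaves open whether nitro in place of hydrogen changes the read-out at all.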